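Cyclohexylamino-to-trimethoxyanilino swap on the pyrazolopyridine amidine series

The compounds below may be only part of what the source reports. "The series", "measured", "known", "first", "only" and "open" are said of these compounds alone.

Measured compounds:
compound 1, `COc1ccc(Cn2nc(-c3ccccc3)c3cc(C(=N)Nc4ccccc4)nc(NC4CCCCC4)c32)cc1`: 3400 nM
compound 2, `COc1ccc(Cn2nc(-c3ccccc3)c3cc(C(=N)Nc4ccc(N5CCN(C)CC5)cc4)nc(NC4CCCCC4)c32)cc1`: 640 nM
compound 3, `COc1ccc(Cn2nc(-c3ccccc3)c3cc(C(=N)Nc4ccccc4)ncc32)cc1`: 4700 nM

Compound 1 gives 3400 nM in a functional assay on HT-1080 cells (Homo sapiens) for cytotoxicity, read by MTT assay, with a stated time of 72 h (a higher number here means a weaker inhibitor, a lower number a stronger inhibitor), the second highest of the three numbers; compound 3 sits nearest with 4700 nM, and compound 2, furthest away, gives 640 nM.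

Compound 4, `COc1ccc(Cn2nc(-c3ccccc3)c3cc(C(=N)Nc4ccccc4)nc(Nc4cc(OC)c(OC)c(OC)c4)c32)cc1`, carries 3,4,5-trimethoxyphenyl in place of cyclohexyl on a nitrogen on an aromatic ring. Within the data shown here, no measured step touches this position with an aromatic group, so the bearing of the data is indirect. The step of a 1.4-fold higher number from compound 1 to compound 3 (0.14 log units; within the scatter) shows that removing the cyclohexylamino altogether changes little, which suggests the site tolerates variation. The step of a 5.3-fold lower number from compound 1 to compound 2 (0.73 log units; beyond the scatter), a modest gain, concerns a different part of the molecule and offers no guide to the new group here.

The expectation for compound 4 is therefore a step of a 1.4-fold lower number from compound 1 to compound 4 (0.13 log units; within the scatter), roughly within the scatter, and its estimated number is 2500 nM, expected between 800 nM and 8000 nM.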

Compound 4, half-maximal inhibitory concentration: 11100 nM
Estimate against measurement, compound 4: 4.4-fold (0.65 log units) below; measured number above the stated range.
By their numbers in this assay, from the lowest: compound 2; then compounds 1 and 3 (each within the scatter of the next); then compound 4.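

In this assay the exchange of cyclohexyl for 3,4,5-trimethoxyphenyl on the nitrogen gives a 3.3-fold higher number from compound 1 to compound 4 (0.51 log units; beyond the scatter), a modest step but one beyond the scatter, so this position is not indifferent to what it carries. The earlier step of a 1.4-fold higher number from compound 1 to compound 3 (0.14 log units; within the scatter) stays within the scatter, so the tolerance seen on removing the cyclohexylamino does not extend to this replacement. No measured information accounts for the step.

From the compounds shown here alone, it remains open whether an unsubstituted phenyl or a small alkyl such as methyl on this nitrogen would read like compound 1 or like compound 4. Going by these compounds, it is also open whether the 4-methylpiperazin-1-yl change behind a 5.3-fold lower number from compound 1 to compound 2 (0.73 log units; beyond the scatter) would give a similar step on compound 4.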